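The source may report more compounds than this note shows. Statements on the series, on what has been measured and on what is new or still open speak of the compounds shown alone.

Working notes on a short urea series, all members sharing one core and examined in an ADME assay on BJ cells (Homo sapiens) for cytotoxicity, with a stated time of 72 h; on this read-out lower numbers stand for an effect already at smaller amounts and higher numbers for an effect only at larger amounts of compound.

Compound 2 `Cc1cc(NC(=O)Nc2cccc(F)c2)c2ccccc2n1` serves as the reference point. In this assay compound 2 gives > 25000 nM, which is a limit of the assay and not a number. Compound 1 `Cc1cc(NC(=O)Nc2cccc([N+](=O)[O-])c2)c2ccccc2n1` differs from compound 2 by nitro in place of fluoro on an aromatic carbon. In this assay compound 1 gives > 25000 nM, again a limit. The step that the two limits leave unreadable from compound 2 to compound 1 therefore cannot be sized. Compound 3 `Cc1cc(NC(=O)Nc2ccccc2F)c2ccccc2n1` differs from compound 2 by 2-fluorophenyl in place of 3-fluorophenyl on an amide-type nitrogen. In this assay compound 3 gives > 25000 nM, also a limit. The step that the two limits leave unreadable from compound 2 to compound 3 is likewise unreadable. Across the set the only evidence is the limit of > 25000 nM in this assay, at which 3 of the 3 values shown sit.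

Compound 4 `Cc1cc(NC(=O)Nc2ccccc2[N+](=O)[O-])c2ccccc2n1` is not yet measured; it differs from compound 3 by nitro in place of fluoro on an aromatic carbon. This is the same kind of change as from compound 2 to compound 1, but the place differs: meta to a large group there, ortho to a large group here. The expected step is a step that the limit leaves unreadable from compound 3 to compound 4, resting on the unreadable step that the two limits leave unreadable from compound 2 to compound 1. For compound 4 the estimated value in this assay is 40000 nM, spanning 20000 nM to 120000 nM, and most likely the assay again reports only a limit.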

Compound 4, half-maximal effective concentration in the BJ assay: > 25000 nM
Compound 4: no number, only a limit (the forecaster's own chance of this, stated with the estimate: 85%); the middle value does not contradict the limit.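

In the BJ assay compound 3 gives > 25000 nM, which is a limit of the assay and not a number. In the BJ assay compound 4 gives > 25000 nM, which is also a limit of the assay and not a number. No step can be read from compound 3 to compound 4 in the BJ assay, where both compounds, like the rest of the series, give only a limit of the assay and not a number: the limit of > 25000 nM in the BJ assay, at which 4 of the 4 values shown sit.

In a physicochemical assay for solubility, at pH 7.4 (a lower number here means a less soluble compound, a higher number a more soluble compound), compound 3 gives 3800 nM. In the physicochemical assay compound 4 gives 200 nM. In the physicochemical assay the change of nitro in place of fluoro on an aromatic carbon is a 19-fold lower number from compound 3 to compound 4 (1.28 log units; beyond the scatter).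

The compounds shown leave open whether any member of the series has a measurable effect in the BJ assay, and at what concentration.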